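The source may report more compounds than this note shows. Statements on the series, on what has been measured and on what is new or still open speak of the compounds shown alone.

Compound 1, `O=C(O)CCc1ccc2oc(-c3ccccc3)cc2c1`: 92% in a functional assay on 1321-N1 cells for agonist activity at Free fatty acid receptor 1 (Homo sapiens), read by calcium flux; on this read-out lower numbers stand for smaller maximal responses and higher numbers for larger maximal responses.
Compound 2, `N#Cc1cccc(COc2ccc(CCC(=O)O)cc2)c1`: 102% in this assay.

Both measured compounds reach a near-complete maximal response in this assay. Compound 2 holds the numerically upper of the two values, but its gap to compound 1 lies within the usual scatter of repeated measurements, so the two cannot be separated on these numbers. Within the data shown here, no two measured compounds differ in only one place, so no measured step is available to guide what a single change does to the maximal response.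

Compound 3, `O=C(O)CCc1ccc(OCc2cccc(-c3ccccc3)c2)cc1`, has not yet been measured. It differs from compound 2 as follows: phenyl in place of cyano on an aromatic carbon. The rest of the structure is unchanged. Because compound 2 already gives 102% and compound 1 gives 92%, the change is expected to leave the maximal response at about the same level, with a step no larger than the scatter; the expected step here is a number 5 percentage points lower from compound 2 to compound 3 (within the scatter). Compound 3 is therefore estimated to give 97% in this assay, with a likely range from 78% to 112%.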

Compound 3, largest response reached (reported as efficacy), in percent of the reference or control that the assay uses: 105%
For compound 3 the middle estimate is 8 percentage points below the measured one, and the stated range covers the measured number.
By their numbers in this assay, from the lowest: compounds 1, 2 and 3 (each within the scatter of the next, the first and the last beyond it).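

Among these compounds, the nitrile-to-phenyl swap is the first single change that can be read here, and in this assay the step is a number 3 percentage points higher from compound 2 to compound 3 (within the scatter) and so leaves the two compounds inseparable. On this aromatic carbon, meta to a large group, the 2 heavy atoms of cyano can thus give way to the 6 heavy atoms of a whole phenyl ring with no measurable change in maximal response. The hydrogen-bond acceptor of cyano also leaves in this swap, so compound 3 keeps a near-complete maximal response without that acceptor at this position. Nothing available here gives a reason for this tolerance.

On these data alone, whether an amine or a carboxylic acid on this same carbon would keep the maximal response remains open, as does whether a phenyl ring on a different carbon of this ring would do so. As far as these compounds go, the maximal response also says nothing about how much of each compound is needed to reach it, so any difference in that respect between the nitrile and the phenyl compound remains unknown.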